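A Heteroaryl Replacement on the Pendant Ring

A few compounds are considered here, and "the series" means these few. Any claim that something is new, unique, unknown or untested is made for them only; others in the source may bear on it.

Compound 1 `CN1CCC[C@H]1COc1cncc(-c2ccccc2)c1` carries a plain phenyl group on the shared core, and in an assay on membranes from brain for binding affinity to Neuronal acetylcholine receptor; alpha4/beta2 (Rattus norvegicus) (on this read-out lower numbers stand for stronger inhibition and higher numbers for weaker inhibition), compound 1 gives 0.11 nM. Compound 2 `Cc1ccccc1-c1cncc(OC[C@@H]2CCCN2C)c1` gives 1.1 nM in this assay, and compound 3 `CN1CCC[C@H]1COc1cncc(-c2ccc(Cl)cc2)c1` gives 0.082 nM. The steps among these show a 10-fold higher number from compound 1 to compound 2 (1.00 log units; beyond the scatter) and a 1.3-fold lower number from compound 1 to compound 3 (0.13 log units; within the scatter), while a 13-fold lower number from compound 2 to compound 3 (1.13 log units; beyond the scatter). Compound 3 and compound 1 are indistinguishable within the scatter, and both sit well apart from compound 2. Compound 4 `CN1CCC[C@H]1COc1cncc(-c2cccnc2)c1` differs from compound 3 by pyridin-3-yl in place of 4-chlorophenyl on an aromatic carbon. Among the measured compounds shown here, the steps that bear on this alter the same pendant ring: the step from compound 1 to compound 3 stayed within the scatter, whereas the step from compound 2 to compound 3 was large. For the measured compounds named here, no measured compound carries a ring nitrogen in the pendant ring, so the expectation rests on the tolerance seen between compound 1 and compound 3. Compound 4 is expected to show a 2.4-fold higher number from compound 3 to compound 4 (0.39 log units; beyond the scatter), a modest rise that may stay within the scatter. The estimate for compound 4 is 0.2 nM, with a range from 0.05 nM to 0.8 nM.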

Compound 4, inhibition constant: 0.27 nM
Compound 4: middle estimate off by 1.4-fold (0.13 log units), on the low side; the measured number falls inside the stated range.
By their numbers in this assay, from the lowest: compounds 3 and 1 (each within the scatter of the next); then compound 4; then compound 2.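

In this assay, the pendant ring proves less forgiving of a ring nitrogen than of a chloro group: pyridin-3-yl in place of phenyl gives a 2.5-fold higher number from compound 1 to compound 4 (0.39 log units; beyond the scatter), whereas the chloro step stayed within the scatter. Set against the 4-chlorophenyl group, the pyridin-3-yl group gives a 3.3-fold higher number from compound 3 to compound 4 (0.52 log units; beyond the scatter), so neither of the two lowest compounds is matched by the ring carrying nitrogen. The rise remains limited, however, since pyridin-3-yl in place of 2-methylphenyl gives a 4.1-fold lower number from compound 2 to compound 4 (0.61 log units; beyond the scatter).

Nothing available explains why the ring nitrogen raises the number. The compounds shown leave open whether moving the nitrogen to another place in the pendant ring changes the result, and how an amine or a carboxylic acid on that ring would compare.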